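Methoxy in place of hydrogen at the assay limit

The source may hold more compounds than are shown below. What is called first, only, known or untested is meant among the compounds shown, and "the series" means these compounds.

Compound 2 `Cc1cccc(-c2nn3c(c2-c2ccncc2)C(C)C(C)(C)C3)n1` offers no measured number in a functional assay on K562 cells (Homo sapiens) for cytotoxicity, with a stated time of 72 h; on this read-out higher numbers stand for weaker inhibition and lower numbers for stronger inhibition. There, compound 2 reads > 100000 nM, which is a limit. The same holds for its hydroxy counterpart, compound 1 `Cc1cccc(-c2nn3c(c2-c2ccncc2)C(CO)C(C)(C)C3)n1`. Compound 1 reads > 100000 nM, also a limit. Together, compound 1 and compound 2 stand at the limit of > 100000 nM in this assay, at which 2 of the 2 values shown sit. Compound 3 `COCC1c2c(-c3ccncc3)c(-c3cccc(C)n3)nn2CC1(C)C` carries methoxy in place of hydrogen on a saturated chain carbon bound to a saturated ring carbon. Going by the values given here, the only measured step, a step that the two limits leave unreadable from compound 1 to compound 2, puts hydrogen in place of hydroxy at that same place, and its size cannot be read. With neither end of that step giving a number, no shift beyond the scatter is expected in either direction, and the expected step is a number no higher from compound 2 to compound 3 (the limit leaves the size open). Compound 3 is expected to read 100000 nM, with an estimated range of 50000 nM to 200000 nM.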

Compound 3, half-maximal inhibitory concentration: > 100000 nM
Compound 3 ended at the assay's limit; the forecaster's own chance of this, stated with the estimate: 85%; the middle value lies on the limit itself.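

Going by these compounds alone, no step among compound 1, compound 2 and compound 3 can be read in this assay, because each gives only a limit: the limit of > 100000 nM in this assay, at which 3 of the 3 values shown sit. The compounds shown leave open whether hydroxy, hydrogen and methoxy at this place differ at all in their effect on these cells.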